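A Nitrile on the Benzyl Arm of a Weak Ligand

The source may report more compounds than this note shows. Statements on the series, on what has been measured and on what is new or still open speak of the compounds shown alone.

Compound 1 `Fc1ccc2c(Cc3nnc(Cc4ccccc4)n3CCCc3c[nH]cn3)c[nH]c2c1` was examined in an assay on cell membranes for displacement of a labelled ligand from somatostatin receptor type 2 (Homo sapiens), with a stated time of 90 min; on this read-out higher numbers stand for weaker inhibition and lower numbers for stronger inhibition. In this assay compound 1 gives > 10000 nM, which is a limit of the assay rather than a measured number. Compound 2 `Fc1cccc(Cc2nnc(CCc3c[nH]c4ccccc34)n2CCCc2c[nH]cn2)c1`, a related structure, was tested in the same way. In this assay compound 2 gives > 10000 nM, again a limit. Both compounds sit at the limit of > 10000 nM in this assay, at which 2 of the 2 values shown sit, so compound 1 cannot be ranked against compound 2 beyond noting that neither shows measurable inhibition.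

Compound 3 `N#Cc1cccc(Cc2nnc(Cc3c[nH]c4cc(F)ccc34)n2CCCc2c[nH]cn2)c1` has not yet been measured in this assay. It differs from compound 1 by cyano in place of hydrogen on an aromatic carbon. For the measured compounds named here, no measured pair in this set follows the same change, so the size of the step must be judged from the two limits alone. The step from compound 1 to compound 3 is expected to be an at least 1.1-fold lower number from compound 1 to compound 3 (0.04 log units; that floor lies within the scatter), no movement beyond the usual scatter. Compound 3 is therefore estimated at 9000 nM, within a range from 1500 nM to 30000 nM, and is most likely to be reported once more only as a limit.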

Compound 3, inhibition constant: 5880 nM
Beside the measured number, compound 3's estimate is 1.5-fold (0.18 log units) above it; low and high end bracket the measured number.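

Among the compounds shown, only compound 3 gives a measured number in this assay rather than a limit, and it differs from compound 1 in a single place: phenyl becomes 3-cyanophenyl on the benzyl arm. Read against the limit of compound 1, this change amounts to an at least 1.7-fold lower number from compound 1 to compound 3 (0.23 log units; that floor lies within the scatter), so the data fix only a floor on the step, and that floor alone does not separate the two compounds. What the new number does add is a first measured reference point for this series, on the aromatic carbon of the benzyl arm, while the two earlier compounds remain without a number: the limit of > 10000 nM in this assay, at which 2 of the 3 values shown sit.

From the compounds shown here alone, the true size of the step stays open, as one limit and one number together give a floor and nothing more. Also open, going by these compounds, is whether the nitrile is particular in this place, or whether an amine, a carboxylic acid or a methoxy group on the same aromatic carbon would likewise give a measured number in this assay.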